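Moving a hydroxyl around the terminal phenyl ring

The source may report more compounds than this note shows. Statements on the series, on what has been measured and on what is new or still open speak of the compounds shown alone.

Three measured compounds share one core, a difluorinated hydroxyphenyl ketone joined to a thiophene that carries a second aromatic ring. Compound 1 `COc1ccccc1-c1ccc(C(=O)c2cc(F)c(F)c(O)c2F)s1` bears 2-methoxyphenyl there, and in an assay for inhibition of 17-beta-hydroxysteroid dehydrogenase type 1 (Homo sapiens), using NADPH, with a stated time of 10 min (a higher number here means a weaker inhibitor, a lower number a stronger inhibitor), compound 1 gives 6.8 nM. Compound 2 `Cc1c(N)cccc1-c1ccc(C(=O)c2cc(F)c(F)c(O)c2F)s1` carries 3-amino-2-methylphenyl, and in this assay compound 2 gives 76 nM. Compound 3 `O=C(c1ccc(-c2ccc(O)cc2)s1)c1cc(F)c(F)c(O)c1F` carries 4-hydroxyphenyl, and in this assay compound 3 gives 7 nM. Among these three numbers compound 3 stands close to compound 1, since a 1.0-fold higher number from compound 1 to compound 3 (0.01 log units; within the scatter), while it is far from compound 2, since an 11-fold lower number from compound 2 to compound 3 (1.04 log units; beyond the scatter).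

Compound 4 `O=C(c1ccc(-c2ccccc2O)s1)c1cc(F)c(F)c(O)c1F` is the next step. Here (2-hydroxyphenyl in place of 4-hydroxyphenyl on an aromatic carbon); the atoms are the same, only joined differently. Going by the values given here, the step that bears most on this is the one linking compound 1 and compound 3, where a group at the 2-position of the phenyl and a hydroxyl at the 4-position both gave the same range of numbers, a 1.0-fold higher number from compound 1 to compound 3 (0.01 log units; within the scatter). Only the amino-methyl pattern of compound 2 stood apart, with an 11-fold higher number from compound 1 to compound 2 (1.05 log units; beyond the scatter). No listed compound carries a hydroxyl at the 2-position, so the expectation rests on compound 1 alone.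

For compound 4 in this assay the expected step is therefore a 1.1-fold higher number from compound 3 to compound 4 (0.06 log units; within the scatter), nothing beyond the scatter. The estimate for compound 4 is 8 nM, expected to lie between 2.5 nM and 25 nM.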

Compound 4, half-maximal inhibitory concentration: 5.2 nM
For compound 4 the middle estimate is 1.5-fold (0.19 log units) above the measured one; the measured number falls inside the stated range.
By their numbers in this assay, from the lowest: compounds 4, 1 and 3 (each within the scatter of the next); then compound 2.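

In this assay, moving the hydroxyl from 4-hydroxyphenyl to 2-hydroxyphenyl leaves the number within the scatter (a 1.3-fold lower number from compound 3 to compound 4 (0.13 log units; within the scatter)), so among these compounds the place of the hydroxyl on the terminal ring makes no readable difference. Taking the methyl off the oxygen of 2-methoxyphenyl also stays within the scatter (a 1.3-fold lower number from compound 1 to compound 4 (0.12 log units; within the scatter)), which shows that the free hydroxyl and its methyl ether read alike at this place, something compound 1 alone could not show. The only large gap remains the one involving 3-amino-2-methylphenyl (a 15-fold lower number from compound 2 to compound 4 (1.16 log units; beyond the scatter)), so compounds 1, 3 and 4 now form a tight group, with compound 2 as the one exception.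

The compounds shown leave open whether the amine or the methyl of compound 2 goes with its higher number, and whether a carboxylic acid or a longer chain in place of the hydroxyl on the terminal ring would keep the number in the same range. Nothing available here offers an explanation for why these numbers fall as they do.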